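Swapping the amide side chain on a biphenyl antagonist

The source may hold more compounds than are shown below. What is called first, only, known or untested is meant among the compounds shown, and "the series" means these compounds.

Three compounds have numbers in a functional assay for antagonist activity at thromboxane A2 receptor (Rattus norvegicus); a lower number here means tighter binding, a higher number weaker binding. Compound 1 `O=C(O)CC/C=C\CO[C@H]1[C@@H](OCc2ccc(-c3ccccc3)cc2)CC[C@@H]1N1CCCCC1` has been run twice and gives 31.6 nM; 50.1 nM (2 entries); its repeat is recorded as the several entries of compound 1 in this assay, 31.6 nM; 50.1 nM (2 entries). Compound 3 `O=C(O)CC/C=C\CO[C@@H]1[C@@H](OCc2ccc(-c3ccccc3)cc2)CC[C@@H]1N1CCCCC1` gives 1000 nM. Also relevant is the fact that compounds 1 and 3 differ only in the configuration as drawn, and their numbers lie well apart. Compound 2 `CC(=O)NCc1ccccc1-c1ccc(COC2CC[C@H](N3CCCCCC3)[C@H]2OC/C=C\CCC(=O)O)cc1` gives 126 nM, which is the lower of the two single numbers and stands beyond the scatter away from compound 3, while compound 1 carries two entries rather than one.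

Compound 4 `NC(=O)c1ccccc1-c1ccc(COC2CC[C@H](N3CCCCCC3)[C@H]2OC/C=C\CCC(=O)O)cc1` is not yet measured. It differs from compound 2 in one place: carbamoyl in place of acetamidomethyl on an aromatic carbon. For the measured compounds named here, no measured pair in this set shows what such a change does, so there is no step to lean on. The expectation is that the shorter carbamoyl will behave much like the acetamidomethyl it replaces, with any shift staying within the usual scatter. Compound 4 is therefore estimated at 150 nM, with a plausible range from 50 nM to 500 nM. The step this estimate implies is a 1.2-fold higher number from compound 2 to compound 4 (0.08 log units; within the scatter), which is meant as no real change beyond the scatter rather than a predicted gain or loss.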

Compound 4, dissociation constant: 15.9 nM
The estimate for compound 4 lay 9.4-fold (0.97 log units) above the measured number, outside the stated range (below it).
By their numbers in this assay, from the lowest: compound 4; then compound 2; then compound 3.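

For the compounds shown here, until now no measured pair showed how much this position matters. In this assay, the change from 2-(acetamidomethyl)phenyl to 2-carbamoylphenyl gives a 7.9-fold lower number from compound 2 to compound 4 (0.90 log units; beyond the scatter), a step beyond the usual scatter, so the group on this aromatic carbon, ortho to a large group, clearly affects the number. The two groups have the same counts of hydrogen-bond donors and acceptors and neither carries a net charge, so those counts do not separate them, and the visible differences in the counts are the heavy atoms and the carbons among them; the repeat of compound 1 and the configuration pair of compound 1 and compound 3 do not speak to this swap, and nothing shown gives a reason for the step.

A single pair cannot say which part of the carbamoyl goes with the lower number, and an aminomethyl group, a nitrile or a carboxylic acid on the same carbon would help to separate those parts. Going by these compounds, it also remains open whether the same swap would give a similar step on the core of compound 1.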